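Bromo for methoxy at two places on a shared core

The source may hold more compounds than are shown below. What is called first, only, known or untested is meant among the compounds shown, and "the series" means these compounds.

Measured compounds:
compound 1 `COc1ccc2c(c1)c(-c1nc3ccccc3n1C(=O)c1ccccc1)cn2C` — 38400 nM
compound 2 `COc1ccc2c(c1)c(-c1nc3ccccc3n1C(=O)c1ccccc1OC)cn2C` — 23900 nM
compound 3 `COc1ccc2c(c1)c(-c1nc3ccccc3n1C(=O)c1ccccc1Br)cn2C` — 55800 nM

In a functional assay on MCF7 cells (Homo sapiens) for inhibition, read by MTT assay, with a stated time of 24 h (on this read-out lower numbers stand for stronger inhibition of growth and higher numbers for weaker inhibition of growth), compound 1 gives 38400 nM. Compound 2 gives 23900 nM and compound 3 gives 55800 nM. Compounds 2 and 1 differ only by hydrogen in place of methoxy on an aromatic carbon. The change bromo in place of methoxy on an aromatic carbon produced a 2.3-fold higher number from compound 2 to compound 3 (0.37 log units; beyond the scatter). Compound 4 `Cn1cc(-c2nc3ccccc3n2C(=O)c2ccccc2)c2cc(Br)ccc21` carries the same kind of change, (bromo in place of methoxy on an aromatic carbon); here the place is on a ring that is part of a fused or bridged system of two rings, meta to a fused ring and para to a fused ring, whereas in compound 3 it sits ortho to a large group. Because a 2.3-fold higher number from compound 2 to compound 3 (0.37 log units; beyond the scatter) was only modest, and the place now differs, compound 4 is expected to give a 1.3-fold higher number from compound 1 to compound 4 (0.11 log units; within the scatter) in this assay. Compound 4 is estimated at 50000 nM, with a range from 20000 nM to 125000 nM.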

Compound 4, concentration for 50% growth inhibition: 50300 nM
For compound 4 the middle estimate is 1.0-fold (0.00 log units) below the measured one, within the range that was stated.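

In this assay, bromo in place of methoxy on the ring that is part of a fused or bridged system of two rings gives a 1.3-fold higher number from compound 1 to compound 4 (0.12 log units; within the scatter). Set beside the same change at the other place, the two steps do not separate: the same change on two cores in this assay, a 2.3-fold higher number (0.37 log units; beyond the scatter) from compound 2 to compound 3 and a 1.3-fold higher number (0.12 log units; within the scatter) from compound 1 to compound 4, 1.8-fold (0.25 log units) apart, within the scatter of two such steps. So the change carries from one core to the other without a gap that can be read, but this does not show that the two steps are equal, and a single pair per core gives no rule for other cores in the series.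

Still open, going by these compounds, is how an amine or a carboxylic acid would behave at either place. Also open, on these data alone, is what bromo at both places together would give.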